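The compounds below may be only part of what the source reports. "The series", "measured", "known", "first", "only" and "open" are said of these compounds alone.

Three compounds on a shared core have been examined so far: compound 1 (`O=C(Nc1ccc(NCc2cc(C(F)(F)F)cc(C(F)(F)F)c2)cc1Cl)c1cc(Cl)ccc1O`), compound 2 (`CCCC(C)(C)Nc1ccc(NC(=O)c2cc(Cl)ccc2O)c(Cl)c1`) and compound 3 (`CC(=O)Nc1ccc(NC(=O)c2cc(Cl)ccc2O)c(Cl)c1`). In an ADME assay on A549 cells (Homo sapiens) for cytotoxicity, read by LDH release, with a stated time of 15 h (on this read-out higher numbers stand for lower toxicity in this test and lower numbers for higher toxicity in this test), compound 1 gives 22900 nM and compound 2 gives 23700 nM as its result. These two numbers lie within the usual scatter of repeated measurements, so compound 2 cannot be told apart from compound 1. For compound 3 the record reads "not determined" (no result reported) and so offers no number to compare.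

The next compound is compound 4 (`CCCNc1ccc(NC(=O)c2cc(Cl)ccc2O)c(Cl)c1`), which keeps the core of compound 2 and differs from it in one place (propyl in place of 1,1-dimethylbutyl on a nitrogen on an aromatic ring), with propyl in place of 1,1-dimethylbutyl on a nitrogen on an aromatic ring. Within the data shown here, no two measured compounds differ in one place only, so no measured step can serve as a direct guide. Compound 1 and compound 2 do carry different groups on that nitrogen, yet compound 1 at 22900 nM and compound 2 at 23700 nM show no gap beyond the scatter. The estimated step of a 1.1-fold higher number from compound 2 to compound 4 (0.02 log units; within the scatter) in this assay is therefore expected to stay within the scatter, with no firm direction. For compound 4 the expected value is 25000 nM within an estimated range from 10000 nM to 60000 nM on this evidence.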

Compound 4, half-maximal cytotoxic concentration: 69700 nM
Compound 4: middle estimate off by 2.8-fold (0.45 log units), on the low side; measured number above the stated range.
By their numbers in this assay, from the lowest: compounds 1 and 2 (each within the scatter of the next); then compound 4.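

In this assay, the group on this nitrogen now proves able to move the number: going from 1,1-dimethylbutyl to propyl gives a 2.9-fold higher number from compound 2 to compound 4 (0.47 log units; beyond the scatter), the first gap beyond the scatter among these compounds, and here the higher number stands for lower toxicity in this test. The change removes 3 carbon atoms from the group, and neither group has a ring, a hydrogen-bond donor or acceptor, or a net charge, so by these counts the two differ only in their carbon content and the way it is arranged. Nothing measured here explains why the number rises.

From the compounds shown here alone, with a single step, it remains open whether the shorter chain or the loss of the two methyl branches of 1,1-dimethylbutyl goes with the higher number, and a straight hexyl chain on the same nitrogen would help to separate the two. An ethyl group would show whether the number keeps rising as the chain shortens, while a hydroxyethyl chain would test a group that carries a hydroxyl at this position.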